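The source may hold more compounds than are shown below. What is called first, only, known or untested is meant among the compounds shown, and "the series" means these compounds.

Measured so far in a functional assay on HL-60 cells (Homo sapiens) for cytotoxicity, read by WST assay, with a stated time of 48 h (on this read-out lower numbers stand for stronger inhibition and higher numbers for weaker inhibition), are three compounds.

- Compound 1 `COc1cc(C(c2ccc(O)c(OC)c2)[C@H](C)C(C)C)ccc1O` gives 17000 nM
- Compound 2 `COc1cc(C(c2ccc(O)c(OC)c2)[C@@H](C)C(C)C)ccc1O` gives 20000 nM
- Compound 3 `COC[C@H](C)[C@@H](C)C(c1ccc(O)c(OC)c1)c1ccc(O)c(OC)c1` gives 68000 nM

Compound 3 stands at the weak end of this small set, with the highest number of the three. The two steps that reach it are a 4.0-fold higher number from compound 1 to compound 3 (0.60 log units; beyond the scatter) and a 3.4-fold higher number from compound 2 to compound 3 (0.53 log units; beyond the scatter). Both involve the added methoxy group and say nothing about configuration.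

The next compound is compound 4 `COC[C@@H](C)[C@@H](C)C(c1ccc(O)c(OC)c1)c1ccc(O)c(OC)c1`, and the change is purely one of stereochemistry: the two compounds have the same atoms and bonds and differ only in configuration as drawn: 1 of 2 stereo elements differ; a stereocentre at a saturated chain carbon is drawn R in compound 3 and S in compound 4.

Among the compounds with values here, only one measured step bears on such a change, namely a 1.2-fold higher number from compound 1 to compound 2 (0.07 log units; within the scatter). That step also concerns a stereocentre at a saturated chain carbon, although that pair lacks the methoxy group, so the comparison is imperfect. On that basis, no shift beyond the scatter is expected in this assay, and neither direction is favoured.

The expected step is a 1.1-fold lower number from compound 3 to compound 4 (0.05 log units; within the scatter).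

For compound 4 the estimated value is 60000 nM, with an expected range from 28000 nM to 120000 nM.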

Compound 4, half-maximal inhibitory concentration: 85000 nM
Compound 4: middle estimate off by 1.4-fold (0.15 log units), on the low side; measured number inside the range.
By their numbers in this assay, from the lowest: compounds 1 and 2 (each within the scatter of the next); then compounds 3 and 4 (each within the scatter of the next).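

In this assay, the change of configuration gives a 1.3-fold higher number from compound 3 to compound 4 (0.10 log units; within the scatter), so this stereocentre in the 2-(methoxymethyl)-1-methylpropyl chain does not separate the pair. Compound 4 keeps the distance from the compounds without the methoxy, with a 4.3-fold higher number from compound 2 to compound 4 (0.63 log units; beyond the scatter) and a 5.0-fold higher number from compound 1 to compound 4 (0.70 log units; beyond the scatter), so the chain stands apart from the 1,2-dimethylpropyl compounds in either configuration at this carbon. The gap to compounds 1 and 2 therefore goes with the methoxy and not with this stereocentre: the fact that compounds 3 and 4 differ only in the configuration as drawn.

On these data alone, the other stereocentre of the chain is drawn the same in compound 3 and compound 4, so its role stays open. Also open, as far as these compounds go, is whether a hydroxyl or an amine in place of the methoxy, or a longer chain, would give a similar step.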